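The compounds below may be only part of what the source reports. "The series", "measured", "known", "first", "only" and "open" are said of these compounds alone.

In an in vitro functional assay on HEK285-7 cells for antagonist activity at prostaglandin D2 receptor 2 (Homo sapiens), read by BRET and beta-arrestin recruitment (on this read-out lower numbers stand for smaller maximal responses and higher numbers for larger maximal responses), compound 1 `O=C(O)Cc1sc(C(c2ccc(F)cc2)c2ccc(F)cc2)nc1-c1ccoc1` gives 80%, and compound 2 `O=C(O)Cc1sc(C(c2ccc(F)cc2)c2ccc(F)cc2)nc1-c1ccco1` gives 80%. The step of no change at the digits printed from compound 1 to compound 2 (within the scatter), furan-2-yl in place of furan-3-yl, leaves the maximal response where it was, so compound 2 stands level with compound 1. Compound 3 `Cc1cc(-c2nc(C(c3ccc(F)cc3)c3ccc(F)cc3)sc2CC(=O)O)ccn1` differs from compound 2 by 2-methylpyridin-4-yl in place of furan-2-yl on an aromatic carbon. Going by the values given here, no measured step exchanges a five-membered aromatic ring for a six-membered one, so the only guide is the flat step already seen. The expected step of a number 5 percentage points lower from compound 2 to compound 3 (within the scatter) is therefore small, with no clear direction. Compound 3 is estimated to give 75%, within 55% to 95%.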

Compound 3, largest response reached (reported as efficacy), in percent of the reference or control that the assay uses: 80%
The estimate for compound 3 lay 5 percentage points below the measured number; the range from low to high includes it.
By their numbers in this assay, from the lowest: compounds 1, 2 and 3 (each within the scatter of the next).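

In this assay, the position next to the ring nitrogen accepts a larger, six-membered aromatic ring in place of a five-membered one, with a ring nitrogen instead of the ring oxygen. The maximal response shows this in the step of no change at the digits printed from compound 2 to compound 3 (within the scatter) and the step of no change at the digits printed from compound 1 to compound 3 (within the scatter). No supporting data are available to explain this flat result. Still open, as far as these compounds go, is whether the response would hold with a group that has no aromatic ring at this position, such as an amine or a longer alkyl chain.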